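The source may hold more compounds than are shown below. What is called first, only, known or untested is meant among the compounds shown, and "the series" means these compounds.

Of the compounds shown here, two built on the same core have numbers so far in a functional assay on MDA-MB-231 cells (Homo sapiens) for inhibition, read by MTT assay, with a stated time of 48 h; on this read-out lower numbers stand for stronger inhibition and higher numbers for weaker inhibition. Compound 2 (`COc1ccc(N(C)c2nc(C)nc3ccccc23)cc1OCCN`), which ends in an amino group, gives 682 nM. Compound 1 (`COc1ccc(N(C)c2nc(C)nc3ccccc23)cc1OCCC[Se]C#N`), which instead carries a group holding selenium and a nitrile, gives 815 nM. These two numbers lie within the usual scatter, so compound 2 cannot be ranked against compound 1.

Compound 3 (`COc1ccc(N(C)c2nc(C)nc3ccccc23)cc1OCCCCC[Se]C#N`) is reached from compound 2 by one change: a group of 6 heavy atoms (4 carbon, 1 nitrogen, 1 selenium; no ring) in place of one nitrogen atom, on a saturated chain carbon, two bonds along the chain from an oxygen on an aromatic ring. Going by the values given here, the only measured step that bears on this is a 1.2-fold lower number from compound 1 to compound 2 (0.08 log units; within the scatter). It is a swap of the same kind, run in the opposite direction and involving a smaller group, and it stayed within the scatter. As far as these compounds go, one step is thin evidence, and the larger group of compound 3 is untested, so no clear direction can be argued. The expected change, a 1.1-fold higher number from compound 2 to compound 3 (0.04 log units; within the scatter), is therefore small and not expected to clear the scatter. For compound 3 the estimate in this assay is 750 nM, with an expected range from 300 nM to 1800 nM.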

Compound 3, half-maximal inhibitory concentration: 4410 nM
The estimate for compound 3 lay 5.9-fold (0.77 log units) below the measured number; the measured number lies above the stated range.
By their numbers in this assay, from the lowest: compounds 2 and 1 (each within the scatter of the next); then compound 3.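

In this assay, this position now proves sensitive to what it carries: the earlier swap stayed within the scatter, whereas the new result gives a 6.5-fold higher number from compound 2 to compound 3 (0.81 log units; beyond the scatter). The more telling comparison is a 5.4-fold higher number from compound 1 to compound 3 (0.73 log units; beyond the scatter), as compound 1 and compound 3 share the ending that holds selenium and a nitrile and differ in the length of the chain carrying it, so among these compounds the higher number goes with the longer chain and not with the ending alone. Nothing given here explains why the longer chain comes with a weaker result.

As far as these compounds go, what stays open is whether the number climbs steadily as the chain grows or jumps at one length, since this ending is seen on only these chains. Also open, from the compounds shown here alone, is whether the longer chain has the same effect with a different ending, such as the amino group of compound 2 on that chain, or with a sulfur atom in place of selenium.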